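Swapping the para-bromo for a nitrile on the aryl ring

The source may report more compounds than this note shows. Statements on the series, on what has been measured and on what is new or still open speak of the compounds shown alone.

Compound 2 `CCCCCCCCCCCCCCCCCCNC(=O)[C@H]1CSC(c2ccc(Br)cc2)N1` gives 3700 nM in a functional assay on PPC-1 cells (Homo sapiens) for antiproliferative activity, read by sulforhodamine B assay (a higher number here means a weaker inhibitor, a lower number a stronger inhibitor), the lowest of the two numbers in hand. Its nearest neighbour is compound 1 `CCCCCCCCCCCCCCCCCCNC(=O)[C@H]1CSC(C2CCCCC2)N1`, which in this assay gives 9300 nM; the step of a 2.5-fold lower number from compound 1 to compound 2 (0.40 log units; beyond the scatter) exchanges a saturated ring for an aromatic one carrying bromine. Compound 3 `CCCCCCCCCCCCCCCCCCNC(=O)[C@H]1CSC(c2ccc(C#N)cc2)N1` differs from compound 2 by cyano in place of bromo on an aromatic carbon. Going by the values given here, no measured step exchanges one substituent for another on that aromatic ring, so the one step in hand, from compound 1 to compound 2, bears on it only indirectly by showing the aryl series to be the better-performing one. On that basis compound 3 is expected to fall close to compound 2, with a step of a 1.2-fold higher number from compound 2 to compound 3 (0.09 log units; within the scatter) that may not pass beyond the scatter. The estimate for compound 3 in this assay is 4500 nM, with a range from 1500 nM to 14000 nM.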

Compound 3, half-maximal inhibitory concentration: 5000 nM
The estimate for compound 3 lay 1.1-fold (0.05 log units) below the measured number; the measured number falls inside the stated range.
By their numbers in this assay, from the lowest: compounds 2, 3 and 1 (each within the scatter of the next, the first and the last beyond it).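

In this assay, a 1.4-fold higher number from compound 2 to compound 3 (0.13 log units; within the scatter), so at this aromatic carbon, para to a large group, bromo and cyano cannot be told apart, even though cyano brings a triple bond and a hydrogen-bond acceptor that bromo lacks. The 4-cyanophenyl group also stays within the scatter of cyclohexyl, with a 1.9-fold lower number from compound 1 to compound 3 (0.27 log units; within the scatter), whereas 4-bromophenyl moved beyond it, with a 2.5-fold lower number from compound 1 to compound 2 (0.40 log units; beyond the scatter); the edge over cyclohexyl is therefore secure for the bromo compound only and cannot be claimed for aryl groups in general. Nothing in hand gives a reason for either result.

The compounds shown leave open whether a methoxy group, an amine or a carboxylic acid on this aromatic carbon would separate from bromo and cyano at all. They also leave open how much of the activity depends on the long chain all three compounds share, which a shorter chain would test.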